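A few compounds are considered here, and "the series" means these few. Any claim that something is new, unique, unknown or untested is made for them only; others in the source may bear on it.

Compound 1 `CCc1cnc(N2CCC(CCCNc3ccc4c(c3)C(=O)CC4)CC2)nc1` gives 113% in a functional assay on CHO-K1 cells for agonist activity at Glucose-dependent insulinotropic receptor (Homo sapiens), read by HTRF and cAMP accumulation, with a stated time of 30 min (on this read-out higher numbers stand for larger maximal responses and lower numbers for smaller maximal responses), and on the two numbers in hand it is the higher: the other measured compound, compound 2 `CC(C)(C)OC(=O)N1CCC(CCCNc2ccc3c(c2)C(=O)CO3)CC1`, gives 95% in this assay, a difference beyond the usual scatter. Among the compounds with values here, the two share no single-place change, so no step between measured compounds can be drawn on.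

Compound 3 `CC(C)c1noc(N2CCC(CCCNc3ccc4c(c3)C(=O)CC4)CC2)n1` departs from compound 1 at one place only: 3-isopropyl-1,2,4-oxadiazol-5-yl in place of 5-ethylpyrimidin-2-yl on an amine nitrogen in a ring. Both groups are uncharged, of the same heavy-atom count, and carry no hydrogen-bond donor; the entering group has one more acceptor and a smaller ring with more hetero atoms.

Within the data shown here, with no comparable step to lean on, the account expects a step of a number 8 percentage points lower from compound 1 to compound 3 (within the scatter) that stays within the scatter, since compound 1 already reaches 113%. The estimate for compound 3 in this assay is 105%, between 85% and 120%.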

Compound 3, largest response reached (Emax), in percent of the reference or control that the assay uses: 110%
Compound 3: the middle estimate sits 5 percentage points below what was measured; the measured number falls inside the stated range.
By their numbers in this assay, from the lowest: compound 2; then compounds 3 and 1 (each within the scatter of the next).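

Within the data shown here, on the amine nitrogen in the six-membered ring, 3-isopropyl-1,2,4-oxadiazol-5-yl in place of 5-ethylpyrimidin-2-yl gives a number 3 percentage points lower from compound 1 to compound 3 (within the scatter) in this assay, the first single-place comparison. At this position, then, this read-out does not separate the two groups, even though one has a five-membered aromatic ring and the other a six-membered one, and they differ in their hetero atoms and hydrogen-bond acceptors. Nothing available explains why the two groups read alike.

The compounds shown leave open whether the response would hold with a group at this nitrogen that carries a carboxylic acid or a primary amine. A maximal response also leaves open how compound 1 and compound 3 compare in the concentration they need to act.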